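The compounds below may be only part of what the source reports. "The series", "measured", "known", "first", "only" and "open" are said of these compounds alone.

Measured so far in a functional assay on NC-37 cells (Homo sapiens) for cytotoxicity; on this read-out lower numbers stand for higher toxicity in this test and higher numbers for lower toxicity in this test:
Compound 1 `C[C@H]1[C@H](O)[C@@H](CO)O[C@H]1n1cc(I)c(=O)[nH]c1=O` — in this assay compound 1 reaches only the assay limit of > 100 ug/mL.
Compound 2 `C[C@H]1[C@H](O)[C@@H](CO)O[C@H]1n1cc(F)c(N)nc1=O` — compound 2 gives 0.22 ug/mL.
Compound 3 `C[C@H]1[C@H](O)[C@@H](CO)O[C@H]1n1cc(Cl)c(N)nc1=O` — compound 3 reaches only the assay limit of > 100 ug/mL.

Compound 3 thus sits at the limit of > 100 ug/mL in this assay, at which 2 of the 3 values shown sit, and no number is known for it. For the measured compounds named here, the one measured step, an at least 450-fold higher number from compound 2 to compound 3 (2.65 log units; beyond the scatter), is large and runs up to that limit. Compound 4 `C[C@H]1[C@H](O)[C@@H](CO)O[C@H]1n1cc(I)c(N)nc1=O` differs from compound 3 by iodo in place of chloro on an aromatic carbon. Going by the values given here, no measured step covers an exchange of chloro for iodo. Compound 1, which carries iodo, sits at the limit as well. The expected step of a number no higher from compound 3 to compound 4 (the limit leaves the size open) is therefore none beyond the scatter. Compound 4 is estimated at 100 ug/mL, range 30 ug/mL to 300 ug/mL, most likely reported again only as a limit.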

Compound 4, half-maximal cytotoxic concentration: > 100 ug/mL
Compound 4: only a limit was reported; the forecaster's own chance of this, stated with the estimate: 75%; the middle value sits exactly at the limit.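

In this assay compound 4 gives > 100 ug/mL, a limit and not a number. Iodo in place of fluoro on this aromatic carbon, ortho to an amino group, gives an at least 450-fold higher number from compound 2 to compound 4 (2.65 log units; beyond the scatter), so among the three halogens shown on the amino-bearing core, only fluoro gives a readable number. Chloro and iodo cannot be ranked, and the step between compound 3 and compound 4 cannot be read, because both compounds sit at the same limit: the limit of > 100 ug/mL in this assay, at which 3 of the 4 values shown sit.

Still open, on these data alone, is whether hydrogen, methyl or a nitrile on this carbon would give a readable number. For the compounds shown here, whether that number would come near the one for compound 2 is equally open.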